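Adding a methoxy to the propyl chain of compound 1

A few compounds are considered here, and "the series" means these few. Any claim that something is new, unique, unknown or untested is made for them only; others in the source may bear on it.

Of the compounds shown here, three have been measured in a functional assay on A-375 cells (Homo sapiens) for antiproliferative activity; on this read-out higher numbers stand for weaker inhibition and lower numbers for stronger inhibition. Compound 1, `CCCO/N=C/c1c(N)ncnc1Oc1ccc2[nH]c(C)cc2c1F`, gives 28 nM, the lowest of the three numbers. Going by the values given here, compound 3, `COCCO/N=C/c1c(N)ncnc1Oc1ccc2[nH]c(C)cc2c1F`, gives 233 nM, and compound 2, `CO/N=C/c1c(N)ncnc1Oc1ccc2cccnc2c1`, gives 886 nM, a far higher number than compound 1 on a different core, so no single step connects the two. Among the compounds with values here, the one clean step in this set is an 8.3-fold higher number from compound 1 to compound 3 (0.92 log units; beyond the scatter), and it points to the chain on the oxime oxygen as a sensitive place.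

Compound 4, `COCCCO/N=C/c1c(N)ncnc1Oc1ccc2[nH]c(C)cc2c1F`, has not yet been measured. Its change from compound 1 is methoxy in place of hydrogen on a saturated chain carbon, three bonds along the chain from an oxygen on an unsaturated carbon: the propyl chain of compound 1 is kept and becomes 3-methoxypropyl. Within the data shown here, only the step from compound 1 to compound 3 bears on it, and there a methoxy entering the chain cost potency beyond the scatter. The oxygen in compound 4 sits one bond further out than in compound 3, so a loss of similar kind but possibly smaller size is expected. The expected step is a 3.9-fold higher number from compound 1 to compound 4 (0.59 log units; beyond the scatter), and compound 4 is estimated at 110 nM, with a range from 35 nM to 330 nM.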

Compound 4, half-maximal inhibitory concentration: 300 nM
Beside the measured number, compound 4's estimate is 2.7-fold (0.44 log units) below it; the range from low to high includes it.
By their numbers in this assay, from the lowest: compound 1; then compounds 3 and 4 (each within the scatter of the next); then compound 2.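

In this assay, methoxy in place of hydrogen at the end of the propyl chain gives an 11-fold higher number from compound 1 to compound 4 (1.03 log units; beyond the scatter), so the loss seen with compound 3 is not confined to a methoxy two bonds along the chain from the oxygen on the unsaturated carbon. The two methoxy-bearing chains cannot be told apart on this read-out, with a 1.3-fold higher number from compound 3 to compound 4 (0.11 log units; within the scatter), so in this pair, 2-methoxyethyl and 3-methoxypropyl give the same result within the scatter, and compound 1 with its plain propyl chain remains clearly apart from both. Nothing shown here gives a measured reason for this loss of potency.

From the compounds shown here alone, what remains open is whether the loss follows from the oxygen itself or from the longer chain, a question that a plain butyl or pentyl chain on the shared core would address, since compound 4 differs from compound 1 in both respects. Going by these compounds alone, it is equally open how a hydroxyl or an amine would fare in place of the methoxy of compound 4, as the only group on these chains so far is methoxy.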